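The compounds below may be only part of what the source reports. "The series", "measured", "known", "first", "only" and "open" are said of these compounds alone.

Working notes on the series, all members sharing one core, read in a functional assay on MCF7 cells (Homo sapiens) for inhibition, read by sulforhodamine B assay; on this read-out higher numbers stand for weaker inhibition and lower numbers for stronger inhibition. Compound 1 `O=C1C(NC2CCCC2)=CC(=O)c2c1nc1n2[C@H]2OC[C@@H](O)[C@H]2OC1` carries cyclopentyl on the amine nitrogen. Compound 1 reads > 16000 nM, which is a limit of the assay. Compound 2 `O=C1C(Nc2ccc(Br)cc2)=CC(=O)c2c1nc1n2[C@H]2OC[C@@H](O)[C@H]2OC1` carries 4-bromophenyl at that place and gives 4330 nM. For the measured compounds named here, the exchange of cyclopentyl for 4-bromophenyl is an at least 3.6-fold lower number from compound 1 to compound 2 (0.56 log units; beyond the scatter), the only step of readable size so far. Compound 3 `CCOc1ccc(NC2=CC(=O)c3c(nc4n3[C@H]3OC[C@@H](O)[C@H]3OC4)C2=O)cc1` carries 4-ethoxyphenyl instead. Compound 3 stands at > 4000 nM, which is a limit and not a number. Its two links are a step that the two limits leave unreadable from compound 1 to compound 3 and a step that the limit leaves unreadable from compound 2 to compound 3, so neither gives a size.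

Next is compound 4 `COc1cccc(NC2=CC(=O)c3c(nc4n3[C@H]3OC[C@@H](O)[C@H]3OC4)C2=O)c1`, with 3-methoxyphenyl in place of 4-ethoxyphenyl on an amine nitrogen. Going by the values given here, no step of readable size exchanges one substituted phenyl for another, so no direction can be drawn, and no step beyond the scatter is expected in this assay. The closest number with a phenyl group is that of compound 2 at 4330 nM. The expected step is a step that the limit leaves unreadable from compound 3 to compound 4. The estimate for compound 4 is 6000 nM, with an expected range of 2500 nM to 15000 nM.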

Compound 4, half-maximal inhibitory concentration: 3830 nM
Estimate against measurement, compound 4: 1.6-fold (0.19 log units) above, within the range that was stated.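

In this assay, this position now has its first readable comparison of two substituted phenyl groups on the amine nitrogen, a 1.1-fold lower number from compound 2 to compound 4 (0.05 log units; within the scatter), so 3-methoxyphenyl and 4-bromophenyl cannot be told apart here. The advantage over cyclopentyl seen with 4-bromophenyl also appears with a second phenyl group, an at least 4.1-fold lower number from compound 1 to compound 4 (0.62 log units; beyond the scatter), although this size is only a floor set against a limit; the pattern rests on compound 2 and compound 4, while compound 3 cannot be counted for or against it. The exchange of 4-ethoxyphenyl for 3-methoxyphenyl reads only as a floor, an at least 1.0-fold lower number from compound 3 to compound 4 (0.01 log units; that floor lies within the scatter), and its true size stays unknown because one end of it is a limit: the limit of > 4000 nM in this assay, at which 1 of the 4 values shown sits.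

Open, on these data alone, is how a benzyl group, or a phenyl ring carrying a carboxylic acid or an amine, would read on this nitrogen. Also open, as far as these compounds go, is whether any group at this place can bring the number well under those of compound 2 and compound 4, since the two phenyl groups with readable numbers sit within the scatter of each other.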